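Chloro in Place of Hydrogen: From Compound 1 to Compound 4

The source may report more compounds than this note shows. Statements on the series, on what has been measured and on what is new or still open speak of the compounds shown alone.

Compound 1 `Cc1ccc(Nc2nc(N)nc(COc3cccc(N4CCCC4=O)c3)n2)cc1Cl` is measured in an assay on COS-7 cells for agonist activity at Free fatty acid receptor 1 (Homo sapiens), read by scintillation counting and inositol phosphate accumulation, with a stated time of 90 min (on this read-out higher numbers stand for an effect only at larger amounts of compound and lower numbers for an effect already at smaller amounts), where it gives 820 nM. Among the two numbers at hand this is the lowest; compound 3 `Cc1ccc(Nc2nc(N)nc(COc3cccc(N4CCCS4(=O)=O)c3)n2)cc1Cl` gives 9700 nM in this assay, and the change between them is a 12-fold higher number from compound 1 to compound 3 (1.07 log units; beyond the scatter). Compound 2 `Cc1ccc(Nc2nc(N)nc(COc3cccc(N4CCOCC4=O)c3)n2)cc1Cl` was carried through this assay without a number being reported, "not determined" (no result reported). Compound 4 `Cc1ccc(Nc2nc(N)nc(COc3ccc(Cl)c(N4CCCC4=O)c3)n2)cc1Cl` differs from compound 1 by chloro in place of hydrogen on an aromatic carbon. For the measured compounds named here, none of the measured steps concerns a change of this kind: the one step with a number, the exchange of one ring for another between compound 1 and compound 3, says nothing about a chloro group entering on an aromatic carbon. Going by the values given here, with no comparable step to lean on, the move to compound 4 is expected to stay within the usual scatter, so that the step to compound 4 is expected to be a 1.0-fold lower number from compound 1 to compound 4 (0.01 log units; within the scatter). The estimate for compound 4 in this assay is 800 nM, with a range from 250 nM to 2500 nM.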

Compound 4, half-maximal effective concentration: 2450 nM
For compound 4 the middle estimate is 3.1-fold (0.49 log units) below the measured one; low and high end bracket the measured number.
By their numbers in this assay, from the lowest: compound 1; then compound 4; then compound 3.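

In this assay, the aromatic carbon ortho to a 2-oxopyrrolidin-1-yl group and para to a large group proves not to be indifferent to substitution: chloro in place of hydrogen gives a 3.0-fold higher number from compound 1 to compound 4 (0.48 log units; beyond the scatter), a modest step but one beyond the scatter. For the compounds shown here, the earlier compounds varied only the ring attached to this aromatic ring, so this is the first sign that a single added chlorine atom on the ring itself shifts the number upward, with hydrogen giving the lower number of the pair. Nothing given here explains why this shift occurs. The compounds shown leave open how fluoro, methyl, methoxy or an amine would behave at this same carbon. They also leave open whether chloro here would produce a similar step alongside the other ring of compound 3.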